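A few compounds are considered here, and "the series" means these few. Any claim that something is new, unique, unknown or untested is made for them only; others in the source may bear on it.

Measured so far:
compound 1 `C=CCc1cc(C(C)=O)c(O)cc1OCC#N`, 2%
compound 2 `C=CCc1cc(C(C)=O)c(O)cc1OCCCCC`, 23%

Both were tested in an assay on isolated protein for binding affinity to leukotriene B4 receptor 1 (Homo sapiens), tested at 1 uM; a lower number here means less inhibition, a higher number more inhibition at the concentration tested (going by the name of the read-out). Compound 2 has the highest of the two numbers; its nearest neighbour is compound 1, with a number 21 percentage points higher from compound 1 to compound 2 (beyond the scatter). For the measured compounds named here, that single step, butyl in place of cyano on a saturated chain carbon bound to an oxygen on an aromatic ring, is the only measured change available and it is modest in size.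

Compound 3 `C=CCc1cc(C(C)=O)c(O)cc1OCCCCCC` has not yet been measured. It differs from compound 2 by methyl in place of hydrogen on a saturated chain carbon, five bonds along the chain from an oxygen on an aromatic ring. Going by the values given here, this is a smaller change than the one from compound 1 to compound 2: a chain already present is lengthened by one carbon rather than a cyano being replaced by butyl. A step of roughly that kind, if it shows at all, is expected to be small and to lean upward rather than downward, so compound 3 is expected to show a number 7 percentage points higher from compound 2 to compound 3 (within the scatter) in this assay. The estimate for compound 3 is 30%, within a range from 12% to 50%.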

Compound 3, a percentage reported as inhibition, at one concentration (the size of the read-out at that concentration, not a potency): 9%
Estimate against measurement, compound 3: 21 percentage points above; the measured number lies below the stated range.
By their numbers in this assay, from the lowest: compounds 1 and 3 (each within the scatter of the next); then compound 2.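

In this assay the chain end turns out to be sensitive: a number 14 percentage points lower from compound 2 to compound 3 (beyond the scatter), although the change is only methyl in place of hydrogen, five bonds along the chain from an oxygen on an aromatic ring. The gain seen with butyl in place of cyano therefore does not carry over to pentyl in place of cyano, which gives a number 7 percentage points higher from compound 1 to compound 3 (within the scatter) and leaves those two compounds indistinguishable. Simply adding carbons to this chain does not raise the number across the compounds shown, and nothing available here explains the fall.

Three compounds cannot show whether the number stays low or recovers with a longer chain. Nor do they show what an amine or a carboxylic acid at the end of the chain would do.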